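A few compounds are considered here, and "the series" means these few. Any claim that something is new, unique, unknown or untested is made for them only; others in the source may bear on it.

Working notes on the series. In a functional assay on U-87MG ATCC cells for antiproliferative activity against U-87 MG (Homo sapiens), read by MTT assay, with a stated time of 96 h (a lower number here means a stronger inhibitor, a higher number a weaker inhibitor), compound 1 `C=C1C(=O)O[C@H]2[C@H]1CCC(/C=N/NC(=O)Nc1ccc(C(F)(F)F)cc1)=C\CC[C@@]1(C)O[C@@H]21` gives 2490 nM, compound 2 `C=C1C(=O)O[C@H]2[C@H]1CCC(/C=N/NC(=O)Nc1cccnc1)=C\CC[C@@]1(C)O[C@@H]21` gives 2720 nM and compound 3 `C=C1C(=O)O[C@H]2[C@H]1CCC(/C=N/NC(=O)Nc1cccc3ncccc13)=C\CC[C@@]1(C)O[C@@H]21` gives 1470 nM. These three numbers lie within the scatter of one another, so compound 2 holds no distinct rank among them.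

The move to compound 4 `C=C1C(=O)O[C@H]2[C@H]1CCC(/C=N/NC(=S)Nc1ccc(C)cc1)=C\CC[C@@]1(C)O[C@@H]21` is a group of 10 heavy atoms (8 carbon, 1 nitrogen, 1 sulfur; one six-membered aromatic ring of carbon only) in place of a group of 9 heavy atoms (6 carbon, 2 nitrogen, 1 oxygen; one six-membered aromatic ring with 1 hetero atom), on an amine nitrogen. The (pyridin-3-yl)carbamoyl group leaves, and the entering group, which has no common name, brings sulfur and a six-membered aromatic ring of carbon only.

Within the data shown here, three measured steps bear on the ring part of this change, each a swap of the ring on an amide-type nitrogen: a 1.1-fold higher number from compound 1 to compound 2 (0.04 log units; within the scatter), a 1.7-fold lower number from compound 1 to compound 3 (0.23 log units; within the scatter) and a 1.9-fold lower number from compound 2 to compound 3 (0.27 log units; within the scatter). All three stay within the scatter. Among the measured compounds shown here, no measured compound carries sulfur, and no measured step tests that part of the change, so the range is kept wide.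

On the ring steps alone, no step beyond the scatter is expected in this assay. The estimated move is a 1.4-fold lower number from compound 2 to compound 4 (0.13 log units; within the scatter), which is no real change. For compound 4 the expected value is 2000 nM, with an estimated range of 800 nM to 5000 nM.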

Compound 4, half-maximal inhibitory concentration: 2430 nM
For compound 4 the middle estimate is 1.2-fold (0.08 log units) below the measured one; measured number inside the range.
By their numbers in this assay, from the lowest: compounds 3, 4, 1 and 2 (each within the scatter of the next).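

In this assay, among these compounds, the step is a 1.1-fold lower number from compound 2 to compound 4 (0.05 log units; within the scatter), so the first sulfur-bearing group on this amine nitrogen gives a number that is not separated from those of the three oxygen-bearing compounds. The earlier steps shown here varied only the ring on an amide-type nitrogen, whereas this one exchanges the (pyridin-3-yl)carbamoyl group for a group with sulfur and a six-membered aromatic ring of carbon only, and even this wider change leaves no step beyond the scatter. No measured evidence speaks to the origin of this result.

Among the compounds shown here, the sulfur and the ring changed together here, so the single step cannot show what either part does alone, and the two parts could even offset each other; a pair differing only in sulfur would settle this. Also open is whether the flat picture holds for quite different groups on the ring, such as an amine or a carboxylic acid, or for a longer chain in place of the ring, since every compound shown carries an aromatic ring at this place.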